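The source may hold more compounds than are shown below. What is called first, only, known or untested is meant among the compounds shown, and "the series" means these compounds.

Measured compounds:
Compound 1, `Cc1ccc(-n2ccnc2SCC(=O)Nc2ccc(C)cc2Br)cc1`, in an ADME assay on MT4 cells (Homo sapiens) for cytotoxicity, read by MTT assay (on this read-out lower numbers stand for higher toxicity in this test and higher numbers for lower toxicity in this test), compound 1 gives 80800 nM.
Compound 2, `O=C(CSc1nccn1-c1ccc(Cl)cc1)Nc1ccccc1Br`, in this assay compound 2 reaches only a limit of the assay, reported as > 300000 nM.

Compound 2 therefore stands at the top of the numbers shown: its figure is a limit, not a measured concentration, and (the limit of > 300000 nM in this assay, at which 1 of the 2 values shown sits). Among the measured compounds shown here, compound 1 is the only compound of the pair with a real number, and no step between the two is counted here, so the two values can only be placed side by side.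

The unmeasured compound 3, `Cc1ccc(NC(=O)CSc2nccn2-c2ccc(Cl)cc2)c(Br)c1`, differs from compound 2 by methyl in place of hydrogen on an aromatic carbon. For the measured compounds named here, with no measured step of this kind available, the expected step from compound 2 to compound 3 in this assay is none beyond the scatter, and compound 3 is estimated to sit near the limit as well, an at least 1.2-fold lower number from compound 2 to compound 3 (0.07 log units; that floor lies within the scatter). Compound 3 is expected at 250000 nM, between 80000 nM and 500000 nM.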

Compound 3, half-maximal cytotoxic concentration: 221000 nM
Compound 3: the middle estimate sits 1.1-fold (0.05 log units) above what was measured; the measured number falls inside the stated range.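

In this assay, the change from 2-bromophenyl to 2-bromo-4-methylphenyl can now be read, though only as a floor within the scatter (an at least 1.3-fold lower number from compound 2 to compound 3 (0.13 log units; that floor lies within the scatter)). That reading rests on a limit held by compound 2, not on a number: the limit of > 300000 nM in this assay, at which 1 of the 3 values shown sits. Among the compounds shown here, the first comparison between two real numbers concerns a different place, chloro in place of methyl on an aromatic carbon, and it gives a modest change beyond the scatter (a 2.7-fold higher number from compound 1 to compound 3 (0.44 log units; beyond the scatter)).

On these data alone, how far the methyl itself moves the number stays open, since one end of its step is a limit. Also open, as far as these compounds go, is whether an amine or a carboxylic acid in place of that methyl, or a longer chain there, would shift the read-out beyond the scatter.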